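A few compounds are considered here, and "the series" means these few. Any claim that something is new, unique, unknown or untested is made for them only; others in the source may bear on it.

Three compounds share one core. In a functional assay on MCF7 cells (Homo sapiens) for antiproliferative activity, read by WST assay, with a stated time of 3 days (a higher number here means a weaker inhibitor, a lower number a stronger inhibitor), compound 1 `[N-]=[N+]=Nc1cc(=O)[nH]c(=O)n1[C@@H]1O[C@H](CO)[C@@H](O)[C@H]1O` gives > 50000 nM, which is a limit and not a number. Compound 2 `COC(=O)c1cc(=O)[nH]c(=O)n1[C@@H]1O[C@H](CO)[C@@H](O)[C@H]1O` also gives only a limit, > 50000 nM. Compound 3 `O=c1cc(NO)n([C@@H]2O[C@H](CO)[C@@H](O)[C@H]2O)c(=O)[nH]1` likewise gives a limit, > 50000 nM. Going by the values given here, because of the limit of > 50000 nM in this assay, at which 3 of the 3 values shown sit, none of the measured steps can be read in size: a step that the two limits leave unreadable from compound 1 to compound 2, a step that the two limits leave unreadable from compound 1 to compound 3 and a step that the two limits leave unreadable from compound 2 to compound 3 all remain unreadable. Compound 4 `O=Cc1cc(=O)[nH]c(=O)n1[C@@H]1O[C@H](CO)[C@@H](O)[C@H]1O` differs from compound 2 by hydrogen in place of methoxy on a carbonyl carbon. Among the compounds with values here, no measured step bears on this change with a readable size, so no step beyond the scatter is expected in this assay in either direction. Compound 4 is therefore expected to give 50000 nM, between 20000 nM and 120000 nM, most likely again reported only as a limit. The expected step of a number no higher from compound 2 to compound 4 (the limit leaves the size open) is essentially none.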

Compound 4, half-maximal inhibitory concentration: > 50000 nM
Compound 4: no number, only a limit (the forecaster's own chance of this, stated with the estimate: 85%); the middle value sits exactly at the limit.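

No step from compound 1, compound 2 or compound 3 to compound 4 can be read in size, since all four sit at one limit: the limit of > 50000 nM in this assay, at which 4 of the 4 values shown sit.

Going by these compounds, whether the azido, methoxycarbonyl, hydroxyamino and formyl groups differ at all in this assay stays open.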